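This account rests on a few compounds, and the source may have more. Where it says the series, first, only, none or still open, it means among the compounds named here.

The measured compounds in a functional assay on HCC1806 cells (Homo sapiens) for inhibition, read by sulforhodamine B assay, tested at 10 uM; on this read-out higher numbers stand for more inhibition at the one concentration tested (going by the name of the read-out) and lower numbers for less inhibition:
compound 1 `CN1CCN(c2ccc(C3=NN(C(=O)CCCl)C(c4ccc(N(C)C)cc4)C3)cc2)CC1`, 1.7%;
compound 2 `CN1CCN(c2ccc(C3=NN(S(C)(=O)=O)C(c4ccc(N(C)C)cc4)C3)cc2)CC1`, -18.5%;
compound 3 `Cc1ccc(S(=O)(=O)N2N=C(c3ccc(N4CCN(C)CC4)cc3)CC2c2ccc(N(C)C)cc2)cc1`, 32.2%.

Compound 1 holds the second highest of these three numbers; the nearest to it is a number 20.2 percentage points lower from compound 1 to compound 2 (beyond the scatter), the furthest is a number 30.5 percentage points higher from compound 1 to compound 3 (beyond the scatter).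

Compound 4 `CN(C)c1ccc(C2CC(c3ccc(-n4cncn4)cc3)=NN2C(=O)CCCl)cc1` differs from compound 1 in one place: 1H-1,2,4-triazol-1-yl in place of 4-methylpiperazin-1-yl on an aromatic carbon. Every measured step changes the group on the ring nitrogen, not the group on the aromatic carbon; the largest of them, a number 50.7 percentage points higher from compound 2 to compound 3 (beyond the scatter), compares two sulfonyl groups. So no measured step bears on this change, and there is no precedent for its direction. The step expected for compound 4 is therefore a number 3.3 percentage points higher from compound 1 to compound 4 (within the scatter), not beyond the scatter. The estimate for compound 4 in this assay is 5%, within a range from -15% to 25%.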

Compound 4, a percentage reported as inhibition, at one concentration (the size of the read-out at that concentration, not a potency): -3.4%
For compound 4 the middle estimate is 8.4 percentage points above the measured one; measured number inside the range.
By their numbers in this assay, from the lowest: compound 2; then compounds 4 and 1 (each within the scatter of the next); then compound 3.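

This is the first change shown on the aromatic carbon rather than on the ring nitrogen. In this assay, with (2-chloroethyl)carbonyl kept on the ring nitrogen, replacing 4-methylpiperazin-1-yl with 1H-1,2,4-triazol-1-yl gives a number 5.1 percentage points lower from compound 1 to compound 4 (within the scatter), so this replacement leaves the read-out within the scatter. No measurement shown offers an explanation for this result.

As far as these compounds go, it remains open whether the same replacement would leave the read-out unchanged with (4-methylphenyl)sulfonyl on the ring nitrogen, the group of compound 3, which gives 32.2%. From the compounds shown here alone, how a morpholin-4-yl group on that aromatic carbon would read is also open.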